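The compounds below may be only part of what the source reports. "The series", "measured", "known", "first", "only" and "open" are said of these compounds alone.

Compound 1, `CCOC(=O)c1cccc(-c2ccc(OCC)cc2)n1`, gives 60000 nM in an assay on COS-7 cells for inhibition of patatin-like phospholipase domain-containing protein 2 (Mus musculus); on this read-out lower numbers stand for stronger inhibition and higher numbers for weaker inhibition.
Compound 2, `CCOC(=O)c1ccc(-c2ccc(OCC)cc2)[nH]1`, gives > 200000 nM in this assay; for compound 2 this is a limit of the assay, not a number, (the limit of > 200000 nM in this assay, at which 1 of the 3 values shown sits).
Compound 3, `CCOc1ccc(-c2cccc(S(=O)(=O)NC)c2)cc1`, gives 200000 nM in this assay.

Compound 3 stands highest of the two numbers given; compound 1 gives a lower number, beyond the scatter. Compound 4, `CCOc1ccc(-c2cccc(C(=O)NC)c2)cc1`, is not yet measured. It differs from compound 3 in one place: methylcarbamoyl in place of methylsulfamoyl on an aromatic carbon. Among the compounds with values here, no measured pair shows such a change, so only a small step is expected in this assay, none beyond the scatter, in either direction. The step of a 1.3-fold lower number from compound 3 to compound 4 (0.12 log units; within the scatter) is expected to be small. Compound 4 is expected to give 150000 nM, within a range from 50000 nM to 500000 nM.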

Compound 4, half-maximal inhibitory concentration: > 200000 nM
Compound 4 gave a limit, no number; the forecaster's own chance of this, stated with the estimate: 35%; middle value at least 1.3-fold (0.12 log units) away from the limit.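

Within the data shown here, this pair is the first to differ in one place, and methylcarbamoyl in place of methylsulfamoyl gives a number no lower from compound 3 to compound 4 (the limit leaves the size open) in this assay. So at this position the change brings no gain, though its size cannot be read. The value of compound 4 is a limit of the assay, not a number: the limit of > 200000 nM in this assay, at which 2 of the 4 values shown sit.

As far as these compounds go, it remains open whether a carboxylic acid or an amine on this aromatic carbon would give a lower number in this assay. From the compounds shown here alone, a longer chain in place of the methyl of methylcarbamoyl is equally open.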